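Phenyl for hydrogen on two cores in a cytotoxicity assay

The source may report more compounds than this note shows. Statements on the series, on what has been measured and on what is new or still open speak of the compounds shown alone.

Two pairs share one structural change, phenyl in place of hydrogen on a saturated chain carbon bound to a saturated ring carbon and (phenyl in place of hydrogen on a saturated chain carbon bound to a saturated ring carbon), on the same place in both pairs, so the change is the same in each. Compound 1 `Cc1ncc([N+](=O)[O-])n1CC(O)CSC(=S)N1CCC(C)CC1` and compound 2 `Cc1ncc([N+](=O)[O-])n1CC(O)CSC(=S)N1CCC(Cc2ccccc2)CC1` carry one core; compound 3 `Cc1ncc([N+](=O)[O-])n1CC(O)CN1CCC(C)CC1` and compound 4 `Cc1ncc([N+](=O)[O-])n1CC(O)CN1CCC(Cc2ccccc2)CC1` carry another. How the two cores differ is not broken down here.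

In a toxicity assay on HeLa cells (Homo sapiens) for cytotoxicity, read by MTT assay, with a stated time of 24 h (a higher number here means a weaker inhibitor, a lower number a stronger inhibitor), compound 1 gives 1820000 nM. In this assay compound 2 gives 1320000 nM. The step between them is a 1.4-fold lower number from compound 1 to compound 2 (0.14 log units; within the scatter), so the change left the read-out where it was on the first core.

Compound 3 reaches only a limit in this assay, > 5000000 nM. That value is the ceiling of the assay, (the limit of > 5000000 nM in this assay, at which 1 of the 3 values shown sits), and not a number.

For the second core the same change is made from compound 3 to compound 4. Given that the step of a 1.4-fold lower number from compound 1 to compound 2 (0.14 log units; within the scatter) sat within the scatter on the first core, the step on the second core is expected to be about as small, and the value of compound 4 is expected to be a step that the limit leaves unreadable from compound 3 to compound 4 away from the limit of compound 3. Because compound 3 already stands at > 5000000 nM, the most likely outcome is that compound 4 also reports only a limit. Compound 4 is estimated at 5500000 nM in this assay, with a range of 2500000 nM to 12000000 nM.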

Compound 4, half-maximal inhibitory concentration: 1430000 nM
For compound 4 the middle estimate is 3.8-fold (0.59 log units) above the measured one, and the stated range ends above it.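

In this assay, the change from methyl to benzyl on the core of compound 3 gives an at least 3.4-fold lower number from compound 3 to compound 4 (0.54 log units; beyond the scatter), while the same change on the core of compound 1 gives a 1.4-fold lower number from compound 1 to compound 2 (0.14 log units; within the scatter). This shows a step beyond the scatter on one core and a step within it on the other, so a step within the scatter on one core did not carry over as such to the other core in this pair of pairs; it does not show that the two cores truly respond differently, and the comparison of the two steps stays unresolved: the same change on two cores in this assay, a 1.4-fold lower number (0.14 log units; within the scatter) from compound 1 to compound 2 and an at least 3.4-fold lower number (0.54 log units; beyond the scatter) from compound 3 to compound 4; the limit leaves it open whether they differ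
Compound 3 reports only a limit, > 5000000 nM, which is not a number, and the true size of the step on its core stays unknown: the limit of > 5000000 nM in this assay, at which 1 of the 4 values shown sits.

Open, on these data alone, is how large the step on the core of compound 3 would be if compound 3 had a measured value in this assay, and whether two pairs say anything general about this series. Also open, as far as these compounds go, is how either core would read in this assay with an amine, a carboxylic acid or a longer chain in place of the phenyl, on a saturated chain carbon bound to a saturated ring carbon.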